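This account rests on a few compounds, and the source may have more. Where it says the series, first, only, none or still open, it means among the compounds named here.

In a functional assay on MCF7 cells (Homo sapiens) for antiproliferative activity, read by MTT assay, with a stated time of 48 h (a higher number here means a weaker inhibitor, a lower number a stronger inhibitor), compound 1 `COc1ccc(C(=O)c2ccc3c(c2)C=CC(C)(C)O3)c(NC(=O)CBr)c1` gives 2880 nM and compound 2 `C=C(c1ccc(OC)cc1NC(=O)CO)c1ccc(OC)c2c1C=CC(C)(C)O2` gives 590 nM while compound 3 `C=C(c1ccc(OC)cc1NC(=O)CNC)c1ccc(OC)c2c1C=CC(C)(C)O2` gives 1010 nM and so stands within the scatter of compound 2 and beyond the scatter under compound 1. Compound 4 `C=C(c1ccc(OC)cc1NC(=O)CN(C)C)c1ccc(OC)c2c1C=CC(C)(C)O2` differs from compound 3 by methyl in place of hydrogen on an amine nitrogen and the group changes from methylamino to dimethylamino. Among the measured compounds shown here, the one measured step that bears on this is a 1.7-fold higher number from compound 2 to compound 3 (0.23 log units; within the scatter) for methylamino in place of hydroxy on a saturated chain carbon bound to a carbonyl carbon. For the measured compounds named here, no measured step covers a change on the amine nitrogen itself. No shift beyond the scatter is therefore expected, and the expected step is a 1.0-fold lower number from compound 3 to compound 4 (0.00 log units; within the scatter) in this assay on this reading. Compound 4 is estimated at 1000 nM with an expected range of 450 nM to 2200 nM in this series.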

Compound 4, half-maximal inhibitory concentration: 2580 nM
For compound 4 the middle estimate is 2.6-fold (0.41 log units) below the measured one; measured number above the stated range.
By their numbers in this assay, from the lowest: compounds 2 and 3 (each within the scatter of the next); then compounds 4 and 1 (each within the scatter of the next).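

In this assay, among the compounds shown here, the amine nitrogen responds to substitution: methyl in place of hydrogen gives a 2.6-fold higher number from compound 3 to compound 4 (0.41 log units; beyond the scatter) and is the first measured change on that nitrogen. Dimethylamino in place of hydroxy on the saturated chain carbon bound to a carbonyl carbon gives a 4.4-fold higher number from compound 2 to compound 4 (0.64 log units; beyond the scatter) and, unlike the methylamino replacement, lies beyond the scatter. No measured evidence accounts for this shift.

From the compounds shown here alone, whether a primary amine on that chain carbon would read with compound 3 or with compound 4 stays open. So does the effect of an ethyl group or a morpholine ring at this position.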